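The source may hold more compounds than are shown below. What is called first, only, known or untested is meant among the compounds shown, and "the series" means these compounds.

Measured so far:
- compound 1, `O=C1C=CC[C@@H](/C=C/c2ccc(F)cc2)O1`: in a functional assay on MCF7 cells (Homo sapiens) for antiproliferative activity, read by luminescence and CellTiter-Glo, with a stated time of 48 h (on this read-out lower numbers stand for stronger inhibition and higher numbers for weaker inhibition), compound 1 gives > 100000 nM, which is a limit of the assay and not a number.
- compound 2, `O=C1C=CC[C@@H]([C@H]2C[C@@H]2c2ccccc2)O1`: in this assay compound 2 gives 68300 nM.

Compound 2 therefore stands alone as the only number shown in this assay; the other value shown is a limit, as the limit of > 100000 nM in this assay, at which 1 of the 2 values shown sits, records. Among the measured compounds shown here, no pair of measured compounds differs in one place, so no measured step is available to calibrate the next change.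

Compound 3, `O=C1C=CC[C@H]([C@@H]2C[C@H]2c2ccccc2)O1`, has not yet been measured. Relative to compound 2 the change is the two compounds have the same atoms and bonds and differ only in configuration as drawn: 3 of 3 stereo elements differ (all stereocentres are inverted: mirror images); a stereocentre at a saturated ring carbon is drawn S in compound 2 and R in compound 3; a stereocentre at a saturated ring carbon is drawn S in compound 2 and R in compound 3; a stereocentre at a saturated ring carbon is drawn S in compound 2 and R in compound 3.

With no measured step of this kind and compound 2 itself a weak inhibitor, the direction of the change cannot be read from any pair shown. The expectation is a step toward weaker inhibition or none beyond the scatter, with a real chance that this assay reports only a limit. Compound 3 is estimated at 90000 nM in this assay, within 30000 nM to 300000 nM. That estimate means an expected step of a 1.3-fold higher number from compound 2 to compound 3 (0.12 log units; within the scatter).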

Compound 3, half-maximal inhibitory concentration: > 100000 nM
Compound 3 ended at the assay's limit; the forecaster's own chance of this, stated with the estimate: 50%; middle value at least 1.1-fold (0.04 log units) away from the limit.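

Among the compounds shown here, compounds 2 and 3 give the first readable step, and it concerns configuration alone: in this assay the step is an at least 1.4-fold higher number from compound 2 to compound 3 (0.16 log units; that floor lies within the scatter). From the compounds shown here alone, compound 3 gives > 100000 nM, which is a limit of the assay and not a number, so the true size of the step stays unknown and the floor does not establish a preference for either mirror image. Any real gap within this pair could come only from configuration, because nothing else separates the two structures: the fact that compounds 2 and 3 differ only in the configuration as drawn

Going by these compounds, with so few values shown, the read-out leaves little room to rank these compounds: the limit of > 100000 nM in this assay, at which 2 of the 3 values shown sit. Still open are whether an amine, a carboxylic acid or a longer chain on the shared core would bring a value clear of this limit, and whether the configuration would matter on a compound with a lower number in this assay.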